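Thiosemicarbazone series: hydroxy to dimethylamino on the benzylidene ring

This account rests on a few compounds, and the source may have more. Where it says the series, first, only, none or still open, it means among the compounds named here.

Measured compounds:
- compound 1, `CC1=CC[C@H](C(C)(C)NC(=S)N/N=C/c2ccccc2)CC1`: 9900 nM
- compound 2, `COc1ccc(/C=N/NC(=S)NC(C)(C)[C@H]2CC=C(C)CC2)cc1`: 8900 nM
- compound 3, `CC1=CC[C@H](C(C)(C)NC(=S)N/N=C/c2ccc(O)cc2)CC1`: > 100000 nM

All three share the same core and differ only in the substituent on the benzylidene ring. In a functional assay on 786-0 cells (Homo sapiens) for inhibition, read by sulforhodamine B assay, with a stated time of 48 h (on this read-out lower numbers stand for stronger inhibition of growth and higher numbers for weaker inhibition of growth), compound 1 gives 9900 nM and compound 2 gives 8900 nM; the step of a 1.1-fold lower number from compound 1 to compound 2 (0.05 log units; within the scatter) lies within the scatter. For compound 3 only a limit is reported, > 100000 nM in this assay, so compound 3 stands at the weak end of the numbers shown, at the limit of > 100000 nM in this assay, at which 1 of the 3 values shown sits. The steps leading there are an at least 10-fold higher number from compound 1 to compound 3 (1.00 log units; beyond the scatter) and an at least 11-fold higher number from compound 2 to compound 3 (1.05 log units; beyond the scatter), both beyond the scatter.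

Compound 4, `CC1=CC[C@H](C(C)(C)NC(=S)N/N=C/c2ccc(N(C)C)cc2)CC1`, has not been measured in this assay. Its change from compound 3 is dimethylamino in place of hydroxy on an aromatic carbon. Within the data shown here, the steps that bear on it are an at least 10-fold higher number from compound 1 to compound 3 (1.00 log units; beyond the scatter) and an at least 11-fold higher number from compound 2 to compound 3 (1.05 log units; beyond the scatter): the hydroxy compound 3 sits far above the hydrogen compound 1 and the methoxy compound 2. Dimethylamino, like methoxy, carries no hydrogen-bond donor, so the expectation is a return toward the numbers of compound 1 and compound 2, that is, an expected step of an at least 10-fold lower number from compound 3 to compound 4 (1.00 log units; beyond the scatter) in the direction of stronger inhibition of growth; because the value of compound 3 is only a limit, the true size of this step is uncertain. Compound 4 is estimated at 10000 nM in this assay, with a range from 3000 nM to 40000 nM.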

Compound 4, concentration for 50% growth inhibition: 87000 nM
Compound 4: the middle estimate sits 8.7-fold (0.94 log units) below what was measured; measured number above the stated range.
By their numbers in this assay, from the lowest: compounds 2 and 1 (each within the scatter of the next); then compound 4. At a limit, above all of these: compound 3.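

In this assay, dimethylamino on this aromatic carbon, para to a large group, does not stay with hydrogen or methoxy: the series shows an 8.8-fold higher number from compound 1 to compound 4 (0.94 log units; beyond the scatter) and a 9.8-fold higher number from compound 2 to compound 4 (0.99 log units; beyond the scatter), both beyond the scatter, while against hydroxy it shows an at least 1.1-fold lower number from compound 3 to compound 4 (0.06 log units; that floor lies within the scatter). Among these compounds, compound 2 and compound 4 both carry no hydrogen-bond donor on this carbon and still stand apart, so the absence of a donor does not by itself keep a group in the range of compound 1 and compound 2, which the earlier compounds could not show. The step between the hydroxy and dimethylamino compounds cannot be read as a size, and compound 4 cannot be placed firmly against compound 3, because compound 3 is known only as a limit: the limit of > 100000 nM in this assay, at which 1 of the 4 values shown sits.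

The compounds shown leave open whether the rise at compound 4 follows the nitrogen or the larger group, which an unsubstituted amine and an ethoxy group on the same carbon would begin to separate. Also open, going by these compounds, is how a carboxylic acid at this place would compare, and whether any group here gives a lower number than compound 1 and compound 2.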